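The source may hold more compounds than are shown below. What is called first, only, known or untested is meant among the compounds shown, and "the series" means these compounds.

Measured in an ADME assay on HEK293 cells (Homo sapiens) for cytotoxicity, read by resazurin assay, with a stated time of 48 h; a lower number here means that less compound is tolerated, a higher number that more compound is tolerated:

- compound 1 `COc1ccc(S(=O)(=O)Nc2ccc3oc(-c4ccc(NC(=O)c5cccc(C)c5[N+](=O)[O-])cc4)nc3c2)cc1`: 12000 nM
- compound 2 `COc1ccc(S(=O)(=O)Nc2ccc3oc(-c4ccc(NS(=O)(=O)c5cc(Br)ccc5OC)cc4)nc3c2)cc1`: 18000 nM
- compound 3 `COc1ccc(S(=O)(=O)Nc2ccc3oc(-c4ccc(NS(=O)(=O)c5cc(F)ccc5OC)cc4)nc3c2)cc1`: 24000 nM

In this assay, compound 3 cannot be told apart from the other two compounds. This is shown by a 1.3-fold higher number from compound 2 to compound 3 (0.12 log units; within the scatter) and by a 2.0-fold higher number from compound 1 to compound 3 (0.30 log units; within the scatter).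

Compound 4 `COc1ccc(S(=O)(=O)Nc2ccc3oc(-c4ccc(NC(=O)C5CCN(C(C)=O)CC5)cc4)nc3c2)cc1` has not yet been measured. Its structure differs from that of compound 3 at one place: a group of 11 heavy atoms (8 carbon, 1 nitrogen, 2 oxygen; one six-membered non-aromatic ring with 1 hetero atom) in place of a group of 12 heavy atoms (7 carbon, 3 oxygen, 1 fluorine, 1 sulfur; one six-membered aromatic ring of carbon only), on a nitrogen on an aromatic ring. The entering group is (1-acetylpiperidin-4-yl)carbonyl.

Two measured steps changed the group on this same nitrogen: a 1.5-fold higher number from compound 1 to compound 2 (0.18 log units; within the scatter) and a 2.0-fold higher number from compound 1 to compound 3 (0.30 log units; within the scatter). Neither moved the number beyond the usual scatter. A change elsewhere, a 1.3-fold higher number from compound 2 to compound 3 (0.12 log units; within the scatter), did not either. However, no measured compound carries a non-aromatic ring at this nitrogen, so these steps are only a loose guide and the range must stay wide.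

No shift beyond the scatter is expected in either direction. The expected step is a 1.1-fold higher number from compound 3 to compound 4 (0.03 log units; within the scatter). Compound 4 is estimated at 26000 nM, with an expected range of 11000 nM to 60000 nM.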

Compound 4, half-maximal cytotoxic concentration: 34000 nM
Beside the measured number, compound 4's estimate is 1.3-fold (0.12 log units) below it, within the range that was stated.
By their numbers in this assay, from the lowest: compounds 1, 2, 3 and 4 (each within the scatter of the next, the first and the last beyond it).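

In this assay, the nitrogen on an aromatic ring now carries a non-aromatic ring, as (1-acetylpiperidin-4-yl)carbonyl, and the number stays within the scatter of both sulfonyl compounds (a 1.4-fold higher number from compound 3 to compound 4 (0.15 log units; within the scatter); a 1.9-fold higher number from compound 2 to compound 4 (0.28 log units; within the scatter)). For the compounds shown here, compound 1 also has a carbonyl on this nitrogen, and 1-acetylpiperidin-4-yl in place of 3-methyl-2-nitrophenyl gives the only step in this set that lies beyond the scatter, though a modest one (a 2.8-fold higher number from compound 1 to compound 4 (0.45 log units; beyond the scatter)). Nothing available here accounts for this step.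

The compounds shown leave open whether an amine or a carboxylic acid in place of the acetyl group would keep the number in this range. They also leave open what a longer open chain on the carbonyl, with no ring at all, would do in this assay at this nitrogen.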